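Azetidine to Piperazine on a Shared Thienopyrimidine Series

The source may report more compounds than this note shows. Statements on the series, on what has been measured and on what is new or still open speak of the compounds shown alone.

Compound 1, `NS(=O)(=O)c1ccc(Nc2ncnc3sc(Nc4c(Cl)cccc4Cl)nc23)cc1`, in a functional assay on HEK293 cells for antagonist activity at transient receptor potential cation channel subfamily V member 1 (Homo sapiens), read by calcium flux; on this read-out higher numbers stand for weaker inhibition and lower numbers for stronger inhibition: > 5000 nM
Compound 2, `FC(F)(F)c1ccc(Nc2nc(N3CCC3)nc3sc(Nc4c(Cl)cccc4Cl)nc23)cc1`, in this assay: 59 nM

Compound 1 reaches only a limit of this assay, (the limit of > 5000 nM in this assay, at which 1 of the 2 values shown sits), so it carries no number. Among the measured compounds shown here, compound 2 therefore stands alone as the single measured value in this assay; no step between two measured compounds is available, and nothing can be said about what the change from compound 1 to compound 2 is worth.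

Compound 3, `FC(F)(F)c1ccc(Nc2nc(N3CCNCC3)nc3sc(Nc4c(Cl)cccc4Cl)nc23)cc1`, has not yet been measured. It differs from compound 2 in one place: piperazin-1-yl in place of azetidin-1-yl on an aromatic carbon. For the measured compounds named here, with no measured step to lean on, the expected shift from compound 2 to compound 3 in this assay is modest, a 2.5-fold higher number from compound 2 to compound 3 (0.41 log units; beyond the scatter), and is estimated to run towards weaker inhibition rather than stronger. On that basis compound 3 is expected to give about 150 nM in this assay, within a range from 30 nM to 800 nM.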

Compound 3, half-maximal inhibitory concentration: 5000 nM
Beside the measured number, compound 3's estimate is 33-fold (1.52 log units) below it, and the stated range ends below it.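

In this assay, the position between two ring nitrogen atoms proves highly sensitive to the amine it carries: piperazin-1-yl in place of azetidin-1-yl gives an 85-fold higher number from compound 2 to compound 3 (1.93 log units; beyond the scatter). This single change enlarges the four-membered ring to a six-membered ring and also adds a second ring nitrogen and a hydrogen-bond donor, so the step cannot assign the shift to any one of these differences. The number for compound 3 stands at the same figure as the one limit in the set: the limit of > 5000 nM in this assay, at which 1 of the 3 values shown sits.

The compounds shown leave open whether ring size or the added nitrogen carries the shift. Piperidin-1-yl, morpholin-4-yl or 4-methylpiperazin-1-yl at this position would help to separate the two.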